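Swapping fluoro for nitro on a methacrylate ketone

The source may hold more compounds than are shown below. What is called first, only, known or untested is meant among the compounds shown, and "the series" means these compounds.

Compound 3 `C=C(C(=O)c1ccc(OC)cc1)C(OC(=O)c1ccccc1)c1ccccc1F` was tested in a functional assay on NB-4 cells (Homo sapiens) for inhibition, read by XTT assay, with a stated time of 48 h (on this read-out lower numbers stand for stronger inhibition and higher numbers for weaker inhibition), where compound 3 gives 14300 nM. Among the three numbers known so far this is the second highest. The nearest is compound 2 `C=C(C(=O)c1ccc(OC)cc1)C(OC(C)=O)c1ccccc1F`, which in this assay gives 9500 nM; the gap to compound 3 lies within the scatter, so the two cannot be ordered. The furthest is compound 1 `COc1ccc(C(=O)/C(=C/c2ccc(Cl)cc2Cl)CC2CCCCC2)cc1`, which in this assay gives 48900 nM, a higher number than compound 3 by a gap beyond the scatter.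

Compound 4 `C=C(C(=O)c1ccc(OC)cc1)C(OC(=O)c1ccccc1)c1ccccc1[N+](=O)[O-]` differs from compound 3 in one place: nitro in place of fluoro on an aromatic carbon. For the measured compounds named here, the only measured step, a 1.5-fold higher number from compound 2 to compound 3 (0.18 log units; within the scatter), concerns the group on the carbonyl carbon, not the six-membered aromatic ring that carries the fluoro, so no measured step bears on this change. With nothing to guide a direction, compound 4 is expected in this assay to stay close to compound 3, the estimated step being a 1.2-fold lower number from compound 3 to compound 4 (0.08 log units; within the scatter), which lies within the scatter. On that basis compound 4 is estimated at 12000 nM, with a range from 4500 nM to 32000 nM.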

Compound 4, half-maximal inhibitory concentration: 12700 nM
Compound 4: middle estimate off by 1.1-fold (0.02 log units), on the low side; the range from low to high includes it.
By their numbers in this assay, from the lowest: compounds 2, 4 and 3 (each within the scatter of the next); then compound 1.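

In this assay, the step of a 1.1-fold lower number from compound 3 to compound 4 (0.05 log units; within the scatter) shows that this position, an aromatic carbon ortho to a large group, can carry nitro in place of fluoro without the read-out separating the two compounds. The earlier compounds shown here with the same shared core had only fluoro here, so they said nothing about this position, whereas the new pair shows that a group of 3 heavy atoms and 2 hydrogen-bond acceptors reads the same, within the scatter, as one of 1 heavy atom and none. No measurement is at hand that would explain this result.

Going by these compounds, with only fluoro and nitro seen at this position, it remains open whether an amine, a carboxylic acid or a longer chain there would also leave the number within the scatter of compound 3, or would move it in either direction. For the compounds shown here, it is also open whether nitro would read the same alongside the methyl on the carbonyl carbon of compound 2, since so far it has been seen only with the phenyl of compound 3.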